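A few compounds are considered here, and "the series" means these few. Any claim that something is new, unique, unknown or untested is made for them only; others in the source may bear on it.

Of the compounds shown here, two have been measured in a functional assay on HEK293 cells for agonist activity at D(4) dopamine receptor (Homo sapiens), read by FLIPR; on this read-out higher numbers stand for an effect only at larger amounts of compound and lower numbers for an effect already at smaller amounts. Compound 1 `Cc1cc(C(=O)NCN2CCC(c3cccc[n+]3[O-])CC2)ccc1F` gives 50 nM there, the higher of the two numbers at hand. Among the compounds with values here, compound 2 `Cc1cccc(NC(=O)CN2CCC(c3ccc(O)cn3)CC2)c1` gives 3.8 nM in this assay, a gap to compound 1 that lies beyond the usual scatter; the two differ in several places at once, so their values show only that compound 1 stands at the weaker end of what has been seen so far.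

Compound 3 `Cc1ccc(C(=O)NCN2CCC(c3cccc[n+]3[O-])CC2)cc1C` has not yet been measured in this assay. It differs from compound 1 in one place: methyl in place of fluoro on an aromatic carbon. Both groups are single heavy atoms without hydrogen-bond donors or acceptors and without net charge, and the amide side of the molecule is otherwise unchanged. Within the data shown here, no measured pair isolates this change, so there is nothing to scale it against; by default a step of this kind is expected to stay within the usual scatter, with no direction preferred.

For compound 3 in this assay the expected value is 50 nM, within 20 nM to 130 nM, which means an expected step of no change at the digits printed from compound 1 to compound 3 (within the scatter).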

Compound 3, half-maximal effective concentration: 38 nM
Estimate against measurement, compound 3: 1.3-fold (0.12 log units) above, within the range that was stated.
By their numbers in this assay, from the lowest: compound 2; then compounds 3 and 1 (each within the scatter of the next).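

In this assay methyl in place of fluoro on an aromatic carbon, ortho to a methyl group and para to a large group, gives a 1.3-fold lower number from compound 1 to compound 3 (0.12 log units; within the scatter) and so leaves 4-fluoro-3-methylphenyl and 3,4-dimethylphenyl indistinguishable on this read-out. Within the data shown here, this is the first pair that isolates one change with the rest of the molecule held fixed, and it shows that, between these two groups of one heavy atom each, the choice at this position does not register beyond the scatter. Nothing at hand accounts for the two groups reading alike, so the result stands as an observation without an explanation.

Still open, going by these compounds, is whether this position responds at all to a group of a different kind, such as an amine, a carboxylic acid, a methoxy group or a longer chain, or to plain hydrogen. Also open, on these data alone, is whether the same exchange reads alike on the core of compound 2, and what in its several differences from compound 1 and compound 3 lies behind its separate place.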